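Changing the Thiophene Attachment in Compound 4

A few compounds are considered here, and "the series" means these few. Any claim that something is new, unique, unknown or untested is made for them only; others in the source may bear on it.

Compound 1 `Cc1csc(-c2cncc(Cl)c2N2CCC3(CCNC3=O)CC2)c1` has been measured in a functional assay on MV4-11 cells (Homo sapiens) for inhibition, read by resazurin assay, with a stated time of 72 h (on this read-out higher numbers stand for weaker inhibition of growth and lower numbers for stronger inhibition of growth), where compound 1 gives 650 nM, the lowest of the three numbers in hand. Compound 2 `O=C1NCCC12CCN(c1c(Cl)cncc1-c1ccc(-c3ccccc3)s1)CC2` gives 960 nM, which sits within the scatter of compound 1, while compound 3 `O=C1NCCC12CCN(c1c(Cl)cncc1-c1ccc(CN3CCCC3)s1)CC2` gives 3370 nM, beyond it. Among the compounds with values here, the one step resolved between neighbours is a 3.5-fold higher number from compound 2 to compound 3 (0.55 log units; beyond the scatter); it exchanges a substituent on the thiophene but leaves the thiophene's attachment to the shared core untouched. Compound 4 `O=Cc1sccc1-c1cncc(Cl)c1N1CCC2(CCNC2=O)CC1` differs from compound 1 by 2-formylthiophen-3-yl in place of 4-methylthiophen-2-yl on an aromatic carbon. Within the data shown here, no measured pair changes the attachment point of the thiophene or brings in a 2-formylthiophen-3-yl group, so the step from compound 2 to compound 3 bears on this change only loosely, as a sign that reworking the thiophene substituent can move the number by a modest amount. Compound 4 is therefore expected to come out somewhat weaker than compound 1, with a 2.3-fold higher number from compound 1 to compound 4 (0.36 log units; beyond the scatter) as the estimated step. Compound 4 is estimated at 1500 nM, with a range from 500 nM to 5000 nM.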

Compound 4, concentration for 50% growth inhibition: 28700 nM
Beside the measured number, compound 4's estimate is 19-fold (1.28 log units) below it; measured number outside the range, above it.
By their numbers in this assay, from the lowest: compounds 1 and 2 (each within the scatter of the next); then compound 3; then compound 4.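

In this assay, placing 2-formylthiophen-3-yl instead of 4-methylthiophen-2-yl on the aromatic carbon ortho to a large group gives a 44-fold higher number from compound 1 to compound 4 (1.64 log units; beyond the scatter). The earlier compounds shown here showed only a modest change on reworking a thiophene substituent, a 3.5-fold higher number from compound 2 to compound 3 (0.55 log units; beyond the scatter), whereas this result shows that a change at this position can cost far more. Compound 4 now has the highest number of the four compounds, and nothing available explains the loss.

The change alters the thiophene's attachment and its substituent together, so the compounds shown leave open which of the two accounts for the step. A 2-methylthiophen-3-yl group, or a 4-formylthiophen-2-yl group, on the same carbon of the shared core would separate the two.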